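Chloropyridyl for phenyl on the alkene carbon of compound 1

The compounds below may be only part of what the source reports. "The series", "measured", "known", "first", "only" and "open" are said of these compounds alone.

Measured so far in a functional assay on MCF7 cells (Homo sapiens) for cytotoxicity, read by CellTiter-Glo, with a stated time of 5 days; a lower number here means a stronger inhibitor, a higher number a weaker inhibitor:
compound 1 `CC/C(=C(/c1ccc(/C=C/C(=O)O)cc1)c1ccc2[nH]ncc2c1)c1ccccc1`, 6 nM
compound 2 `CC/C(=C(\c1ccc2[nH]ncc2c1)c1ccc(/C=C/C(=O)O)cc1OC)c1ccccc1`, 12 nM
compound 3 `CC/C(=C(/c1csc(/C=C/C(=O)O)c1)c1ccc2[nH]ncc2c1)c1ccccc1`, 2900 nM

Compound 1 gives the lowest number of the three in this assay. Compound 2 sits nearest, with a 2.0-fold higher number from compound 1 to compound 2 (0.30 log units; within the scatter), a methoxy in place of hydrogen on an aromatic carbon that makes no difference beyond the scatter. Within the data shown here, compound 3 is furthest; its value and that of compound 1 are far apart, but that pair differs in more than one place and no single step is defined for it.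

Compound 4 `CC/C(=C(/c1ccc(/C=C/C(=O)O)cc1)c1ccc2[nH]ncc2c1)c1ccncc1Cl` differs from compound 1 in one place: 3-chloropyridin-4-yl in place of phenyl on a double-bonded chain carbon bound to a double-bonded chain carbon and a saturated chain carbon. Among the measured compounds shown here, none of the measured steps touches this position; the only defined step, from compound 1 to compound 2, concerns the acid-bearing ring and stays within the scatter. The replacement keeps the ring size and ring count while adding a chlorine and a ring nitrogen. For the measured compounds named here, with no step bearing on this change, a modest effect is expected, the number for compound 4 rising by a 2.0-fold higher number from compound 1 to compound 4 (0.30 log units; within the scatter) at most.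

Compound 4 is therefore estimated at 12 nM in this assay, within a range from 4 nM to 40 nM.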

Compound 4, half-maximal inhibitory concentration: 4 nM
The estimate for compound 4 lay 3.0-fold (0.48 log units) above the measured number, and the stated range covers the measured number.
By their numbers in this assay, from the lowest: compounds 4, 1 and 2 (each within the scatter of the next, the first and the last beyond it); then compound 3.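

In this assay the position on a double-bonded chain carbon bound to a double-bonded chain carbon and a saturated chain carbon now has its first measured step, and 3-chloropyridin-4-yl in place of phenyl gives a 1.5-fold lower number from compound 1 to compound 4 (0.18 log units; within the scatter) and so stays within the scatter. This carbon therefore accepts a chlorine and a ring nitrogen together, with no loss beyond the scatter, and the phenyl of compound 1 is not required here for a low number in this one cell assay. Nothing on hand bears on the reason for this result.

Going by these compounds, the two changes arrive together, so the separate contributions of the chlorine and the ring nitrogen remain open; an unsubstituted pyridinyl ring or a chlorophenyl ring at this carbon would divide them. On these data alone, whether this carbon also accepts a non-aromatic group such as cyclohexyl is equally open.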